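The compounds below may be only part of what the source reports. "The series", "measured", "known", "first", "only" and "open" are said of these compounds alone.

Measured so far in a functional assay on MCF7 cells (Homo sapiens) for cytotoxicity, read by MTT assay; a higher number here means a weaker inhibitor, a lower number a stronger inhibitor:
- compound 1 `CC(=O)CC[C@]1(C(C)=O)C(=O)O[C@@H](OC(C)=O)[C@H]1C`: 6000 nM
- compound 2 `CC(=O)O[C@@H]1OC(=O)[C@@](C(C)=O)(C2SCCCS2)[C@@H]1C`: > 50000 nM (a limit)
- compound 3 `CC(=O)O[C@@H]1OC(=O)[C@](O)(C(C)=O)[C@@H]1C`: > 50000 nM (a limit)

Compound 3 gives > 50000 nM, which is a limit of the assay and not a number. Compound 4 `CC(=O)O[C@@H]1OC(=O)[C@](Br)(C(C)=O)[C@@H]1C` differs from it in one group: bromo in place of hydroxy on a saturated ring carbon. Put simply, this is bromo in place of hydroxy on a saturated ring carbon.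

Two measured steps changed the group on that same carbon, and both went beyond the scatter: an at least 8.3-fold higher number from compound 1 to compound 3 (0.92 log units; beyond the scatter), and an at least 8.3-fold higher number from compound 1 to compound 2 (0.92 log units; beyond the scatter). The third, a step that the two limits leave unreadable from compound 2 to compound 3, cannot be sized. None of these steps involves bromo, so they bear on it only indirectly. Among these compounds, only compound 1 gives a real number, 6000 nM, and the two other groups tried on this carbon both lost that activity. Compound 4 is therefore expected to stay weak in this assay. A small move toward a lower number is expected, shown as an at least 1.6-fold lower number from compound 3 to compound 4 (0.22 log units; that floor lies within the scatter). Compound 4 is estimated at 30000 nM, with an expected range of 8000 nM to 100000 nM.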

Compound 4, half-maximal inhibitory concentration: 17000 nM
Compound 4: the middle estimate sits 1.8-fold (0.25 log units) above what was measured; low and high end bracket the measured number.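

In this assay, bromo is the second group on this saturated ring carbon to give a real number and not a limit, with an at least 2.9-fold lower number from compound 3 to compound 4 (0.46 log units; beyond the scatter) and an at least 2.9-fold lower number from compound 2 to compound 4 (0.46 log units; beyond the scatter). Even so, bromo does not match 2-acetylethyl, with a 2.8-fold higher number from compound 1 to compound 4 (0.45 log units; beyond the scatter). The two lower-number steps give only floors, since compound 2 and compound 3 both stand at a limit of the assay and not at a number: the limit of > 50000 nM in this assay, at which 2 of the 4 values shown sit.

The compounds shown leave open whether chloro, an amine or a longer chain on this carbon would fall nearer to compound 1 or to compound 4. They also leave open the true values of compound 2 and compound 3.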